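A Methoxy Added on the Anilino Ring

The source may report more compounds than this note shows. Statements on the series, on what has been measured and on what is new or still open speak of the compounds shown alone.

Measured compounds:
compound 1 `Cc1nc(SCC(=O)Nc2nc(-c3ccc(Cl)cc3)cs2)n(Nc2ccccc2)c1C` gives 76900 nM
compound 2 `Cc1ccc(Nn2c(SCC(=O)Nc3nc(-c4ccccc4)cs3)nc(C)c2C)cc1` gives > 100000 nM

Among the measured compounds shown here, in a functional assay on HCT-15 cells (Homo sapiens) for antiproliferative activity, read by sulforhodamine B assay, with a stated time of 48 h (a higher number here means that more compound is tolerated, a lower number that less compound is tolerated), compound 1 gives 76900 nM, the only plain number among the two values shown. For compound 2 the value > 100000 nM is a limit of the assay rather than a number, and it sits at the limit of > 100000 nM in this assay, at which 1 of the 2 values shown sits. Compound 3 `COc1ccc(Nn2c(SCC(=O)Nc3nc(-c4ccc(Cl)cc4)cs3)nc(C)c2C)cc1` differs from compound 1 by methoxy in place of hydrogen on an aromatic carbon. For the measured compounds named here, no step between measured compounds is available to guide this change, so the expected step from compound 1 to compound 3 is a 1.0-fold higher number from compound 1 to compound 3 (0.02 log units; within the scatter), a shift not expected to exceed the usual scatter. Compound 3 is therefore estimated at 80000 nM, between 30000 nM and 200000 nM.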

Compound 3, concentration lethal to 50% of the cells: > 100000 nM
Compound 3: a limit, no number; the forecaster's own chance of this, stated with the estimate: 35%; middle value at least 1.2-fold (0.09 log units) away from the limit.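

In this assay compound 3 gives > 100000 nM, which is a limit of the assay and not a number. Replacing phenyl with 4-methoxyphenyl gives an at least 1.3-fold higher number from compound 1 to compound 3 (0.11 log units; that floor lies within the scatter), so methoxy at this position does not bring a lower number, although the true size of the step stays hidden. This change adds a second compound at the same limit: the limit of > 100000 nM in this assay, at which 2 of the 3 values shown sit.

Going by these compounds, it remains open whether an amine or a carboxylic acid at this position on the anilino ring would give a plain number in this assay. On these data alone, how far the true value of compound 3 lies past its limit is also open.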